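The source may report more compounds than this note shows. Statements on the series, on what has been measured and on what is new or still open speak of the compounds shown alone.

Compound 1 (`O=C(/C=C/c1ccccc1C(F)(F)F)c1cccc(O)c1`) stands only at a limit. In a functional assay on RAW264.7 cells (Mus musculus) for inhibition, read by fluorescence, with stated times of 1 h, 24 h and 30 min (a higher number here means a weaker inhibitor, a lower number a stronger inhibitor), compound 1 gives > 10000 nM, which is a limit of the assay and not a number. Compound 2 (`O=C(/C=C/c1ccccc1C(F)(F)F)c1ccc(O)cc1`) carries 4-hydroxyphenyl in place of 3-hydroxyphenyl on a carbonyl carbon. In this assay, compound 2 gives > 10000 nM, which is likewise a limit. Going by the values given here, the only measured step is a step that the two limits leave unreadable from compound 1 to compound 2. The evidence from these two compounds is the limit of > 10000 nM in this assay, at which 2 of the 2 values shown sit, so it gives no size that could be carried over.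

Compound 3 (`O=C(/C=C/c1ccccc1OC(F)(F)F)c1cccc(O)c1`) has trifluoromethoxy in place of trifluoromethyl on an aromatic carbon, ortho to a large group: trifluoromethoxy in place of trifluoromethyl on an aromatic carbon. Among the compounds with values here, no measured step involves this change, and the step at the hydroxyl-bearing group concerns another part of the molecule. No step beyond the scatter is therefore expected in this assay, and no direction can be argued from these data. The expected outcome is a step that the limit leaves unreadable from compound 1 to compound 3. For compound 3 the estimated value is 14000 nM, with an expected range from 4000 nM to 40000 nM.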

Compound 3, half-maximal inhibitory concentration: 1610 nM
Compound 3: the middle estimate sits 8.7-fold (0.94 log units) above what was measured; measured number outside the range, below it.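

The exchange on this aromatic carbon, ortho to a large group, gives the first readable step among these compounds: in this assay, trifluoromethoxy in place of trifluoromethyl, a change that brings in one oxygen, amounts to an at least 6.2-fold lower number from compound 1 to compound 3 (0.79 log units; beyond the scatter). On these data alone, the true size of this step remains unknown: compound 1 gives > 10000 nM, which is a limit of the assay and not a number. The earlier compounds could not show that a change at this position registers in the read-out, and all they offered was this: the limit of > 10000 nM in this assay, at which 2 of the 3 values shown sit.

The compounds shown leave open whether the step belongs to the oxygen link itself or to some other feature of the exchange, and whether the same exchange would carry over to the 4-hydroxyphenyl compound, compound 2. They also leave open how other groups on this aromatic carbon, such as methoxy, chlorine or a nitrile, would read in this assay, and thus whether trifluoromethoxy is unusual there or merely one of many groups that give a measurable number.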